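Cytotoxicity series: terminal aryl variation on a shared core

The source may hold more compounds than are shown below. What is called first, only, known or untested is meant among the compounds shown, and "the series" means these compounds.

Measured so far in an ADME assay on BJ cells (Homo sapiens) for cytotoxicity, read by CellTiter-Glo and resazurin assay, with a stated time of 72 h; a lower number here means that less compound is needed, a higher number that more compound is needed for the effect:
compound 1, `CCOC(=O)CCCCCOc1cccc(CN(C(=O)c2ccc(-c3cccc(Oc4ccccc4)c3)cc2)C(C)C)c1`: > 19600 nM
compound 2, `CCOC(=O)CCCCCOc1cccc(CN(C(=O)c2ccc(-c3cccc(-c4nnc(C)o4)c3)cc2)C(C)C)c1`: > 26000 nM
compound 3, `CCOC(=O)CCCCCOc1cccc(CN(C(=O)c2ccc(-c3cc(OC)cc(OC)c3)cc2)C(C)C)c1`: > 26000 nM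

Compound 3 stands only at a limit in this assay, its value being the limit > 26000 nM. Two of the three values shown sit at the limit of > 26000 nM in this assay, at which 2 of the 3 values shown sit, and one at the limit of > 19600 nM in this assay, at which 1 of the 3 values shown sits. The steps a step that the two limits leave unreadable from compound 1 to compound 2 and a step that the two limits leave unreadable from compound 2 to compound 3 cannot be read in size or direction. The change to compound 4, `CCOC(=O)CCCCCOc1cccc(CN(C(=O)c2ccc(-c3cccc(OC(F)(F)F)c3)cc2)C(C)C)c1`, is 3-(trifluoromethoxy)phenyl in place of 3,5-dimethoxyphenyl on an aromatic carbon. Going by the values given here, no measured step bears on this change beyond the limits. Compound 4 is expected to give a limit again in this assay. The estimate for compound 4 in this assay is 30000 nM (range 15000 nM to 80000 nM). The expected step that the limit leaves unreadable from compound 3 to compound 4 is none beyond the scatter.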

Compound 4, half-maximal effective concentration: > 26000 nM
Compound 4: no number, only a limit (the forecaster's own chance of this, stated with the estimate: 80%); the middle value is on the limit's open side.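

In this assay compound 4 gives > 26000 nM, a limit and not a number. Its steps from compound 1, compound 2 and compound 3 cannot be read. The compounds shown leave open whether any change of the terminal aryl group alters cytotoxicity.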